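The compounds below may be only part of what the source reports. "The series", "measured", "known", "first", "only" and "open" are said of these compounds alone.

Measured compounds so far:
- compound 1 `CC(C)Cc1ccc(-c2ccc3c(c2)C(=O)N(C2CCC(=O)NC2=O)C3=O)cc1` gives 7%
- compound 2 `O=CC#Cc1ccc2c(c1)C(=O)N(C1CCC(=O)NC1=O)C2=O` gives 84%
- compound 3 `CC(C)Cc1ccc(-c2cccc3c2C(=O)N(C2CCC(=O)NC2=O)C3=O)cc1` gives 7%

In a functional assay on Jurkat cells (Homo sapiens) for activation, read by flow cytometry, with a stated time of 24 h, tested at 10 uM (on this read-out lower numbers stand for a weaker effect and higher numbers for a stronger effect at the one concentration tested), compound 3 gives 7%, the same number as compound 1 within the scatter, and the two together sit at the bottom of the three numbers. Compound 2 stands far apart from both, its number being beyond the scatter above compound 3 in this assay. For the measured compounds named here, no pair among the measured compounds differs in only one place, so no single step has been characterised.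

The next compound, compound 4 `CC(C)Oc1ccc(-c2cccc3c2C(=O)N(C2CCC(=O)NC2=O)C3=O)cc1`, is built from compound 3 by one change: isopropoxy in place of isobutyl on an aromatic carbon. Compound 3 and compound 1 both show a low read-out in this assay with the isobutyl group in place, and nothing measured here speaks to what the isopropoxy group does. The estimated step is a number 2 percentage points higher from compound 3 to compound 4 (within the scatter), none beyond the scatter. Compound 4 is expected to give 9% in this assay, with a range from 2% to 28%.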

Compound 4, a percentage reported as activity, at one concentration (the size of the read-out at that concentration, not a potency): 8%
Compound 4: middle estimate off by 1 percentage points, on the high side; the measured number falls inside the stated range.
By their numbers in this assay, from the lowest: compounds 1, 3 and 4 (each within the scatter of the next); then compound 2.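

In this assay, for the compounds shown here, isopropoxy in place of isobutyl on an aromatic carbon, para to a large group, gives a number 1 percentage points higher from compound 3 to compound 4 (within the scatter), the first single-place step that can be read. At this position, the exchange brings in one hydrogen-bond acceptor at the same number of heavy atoms, and the read-out stays level within the scatter. No measurement available here accounts for this outcome.

On these data alone, whether a different group at this position, such as an amine, a carboxylic acid or a longer chain, would shift the read-out remains open. Going by these compounds alone, no single-place step links compound 2 to the other compounds, so the change or changes that separate it from them cannot be read.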